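Removing the Nitro Group from Compound 2

This account rests on a few compounds, and the source may have more. Where it says the series, first, only, none or still open, it means among the compounds named here.

Of the compounds shown here, three have been tested in a functional assay on PC-3 cells (Homo sapiens) for antiproliferative activity, read by MTT assay, with a stated time of 72 h; on this read-out lower numbers stand for stronger inhibition and higher numbers for weaker inhibition. Compound 1 `O=C(COc1ccc(C(=O)/C=C/c2cccc(Cl)c2)cc1)N[C@H]1CCOC1=O` gives 4990 nM, compound 3 `O=C(COc1ccc(C(=O)/C=C/c2ccc(F)c(F)c2)cc1)N[C@H]1CCOC1=O` gives 21900 nM, and compound 2 `O=C1OCC[C@@H]1NC(=S)SCCOc1ccc([N+](=O)[O-])cc1` gives 32500 nM. Compound 2 has the highest number of the three as written, but its difference from compound 3 lies within the scatter, so only its gap to compound 1 counts as a real difference.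

Compound 4 `O=C1OCC[C@@H]1NC(=S)SCCOc1ccccc1` differs from compound 2 in one place: hydrogen in place of nitro on an aromatic carbon. Within the data shown here, the only measured single-point step, a 4.4-fold higher number from compound 1 to compound 3 (0.64 log units; beyond the scatter), concerns a different part of a different scaffold and so says little about the loss of a nitro group. Among the measured compounds shown here, no measured step bears directly on this change. Without such guidance, the step from compound 2 to compound 4 is expected to stay within the scatter, as an expected 1.1-fold lower number from compound 2 to compound 4 (0.03 log units; within the scatter). Compound 4 is therefore estimated at 30000 nM, with a likely range from 10000 nM to 100000 nM.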

Compound 4, half-maximal inhibitory concentration: > 64000 nM
Compound 4 ended at the assay's limit; the forecaster's own chance of this, stated with the estimate: 25%; middle value at least 2.1-fold (0.32 log units) away from the limit.
By their numbers in this assay, from the lowest: compound 1; then compounds 3 and 2 (each within the scatter of the next). At a limit, above all of these: compound 4.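

Compound 4 gives > 64000 nM in this assay, and this is a limit of the assay, not a number: the limit of > 64000 nM in this assay, at which 1 of the 4 values shown sits. Hydrogen in place of nitro on the aromatic ring gives an at least 1.9-fold higher number from compound 2 to compound 4 (0.29 log units; that floor lies within the scatter) and so brings no stronger inhibition at this place, para to a large group, which the earlier compounds could not show. Only a floor is known for this step and it lies within the scatter, so a real loss on removing the nitro group is possible but not established.

Still open, as far as these compounds go, is whether another group at this place, such as an amine, a nitrile or a carboxylic acid, would bring a readable number in this assay and where it would fall relative to compound 2. Also open, from the compounds shown here alone, is how a longer chain to the aromatic ring would read with the nitro group kept.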